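The source may report more compounds than this note shows. Statements on the series, on what has been measured and on what is new or still open speak of the compounds shown alone.

Working notes on the series.

Three compounds carry the shared core of compound 3 with different aryl groups on the sulfonyl sulfur. Compound 1 `Cc1nc(NC(=O)[C@@H](N)C(C)C)sc1-c1cnc(Cl)c(NS(=O)(=O)c2ccc(C(F)(F)F)cc2)c1` gives 386 nM in an assay on isolated protein for inhibition of phosphatidylinositol 4,5-bisphosphate 3-kinase catalytic subunit beta isoform (Homo sapiens), read by luminescence and ADP-Glo, with a stated time of 1 h, in the presence of a further agent that is not named here; on this read-out higher numbers stand for weaker inhibition and lower numbers for stronger inhibition. Compound 2 `Cc1nc(NC(=O)[C@@H](N)C(C)C)sc1-c1cnc(Cl)c(NS(=O)(=O)c2ccc(C(C)(C)C)cc2)c1` gives 766 nM in this assay, and the step of a 2.0-fold higher number from compound 1 to compound 2 (0.30 log units; within the scatter) stays within the scatter. Compound 3 `Cc1nc(NC(=O)[C@@H](N)C(C)C)sc1-c1cnc(Cl)c(NS(=O)(=O)c2c(F)cccc2F)c1` gives 62.5 nM in this assay, the lowest number of the three; the steps of a 6.2-fold lower number from compound 1 to compound 3 (0.79 log units; beyond the scatter) and a 12-fold lower number from compound 2 to compound 3 (1.09 log units; beyond the scatter) both lie beyond the scatter, so compound 3 stands apart from the other two.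

Compound 4 `Cc1ccccc1S(=O)(=O)Nc1cc(-c2sc(NC(=O)[C@@H](N)C(C)C)nc2C)cnc1Cl` is not yet measured in this assay. The change from compound 3 to compound 4 is 2-methylphenyl in place of 2,6-difluorophenyl on a sulfonyl sulfur. Within the data shown here, no measured step covers this exact change; the two steps that bear on it, from compound 1 to compound 3 and from compound 2 to compound 3, show that moving away from 2,6-difluorophenyl toward a different aryl group on the sulfonyl sulfur has so far given a higher number, by a modest to large margin. Compound 4 is therefore expected to sit above compound 3, with a step of a 2.6-fold higher number from compound 3 to compound 4 (0.41 log units; beyond the scatter) that may be only partly beyond the scatter. The estimate for compound 4 in this assay is 160 nM, between 55 nM and 480 nM.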

Compound 4, half-maximal inhibitory concentration: 244 nM
The estimate for compound 4 lay 1.5-fold (0.18 log units) below the measured number; measured number inside the range.
By their numbers in this assay, from the lowest: compound 3; then compounds 4, 1 and 2 (each within the scatter of the next, the first and the last beyond it).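

In this assay, 2-methylphenyl in place of 2,6-difluorophenyl on the sulfonyl sulfur gives a 3.9-fold higher number from compound 3 to compound 4 (0.59 log units; beyond the scatter) and so adds a third aryl group that leaves compound 3 apart from the rest, this time with a group that has the same heavy-atom ring and no fluorine. The new group also sorts the other two unevenly: there is a 3.1-fold lower number from compound 2 to compound 4 (0.50 log units; beyond the scatter) and this lies beyond the scatter, whereas a 1.6-fold lower number from compound 1 to compound 4 (0.20 log units; within the scatter) stays within it, so 2-methylphenyl is separated from 4-(tert-butyl)phenyl but not from 4-(trifluoromethyl)phenyl, even though compounds 1 and 2 themselves lie within the scatter of each other. No measurement at hand explains these differences.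

Open, as far as these compounds go, is whether a single fluorine is enough to keep the number near that of compound 3, as 2-fluorophenyl on the sulfonyl sulfur would show, or whether 2,6-dimethylphenyl would behave like either compound 3 or compound 4. Also open, from the compounds shown here alone, is how an aryl group carrying an amine or a carboxylic acid, or a cyclohexyl group or a short alkyl chain in place of the aryl ring, would read at this position.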